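Swapping the aryl hydroxamate for a cinnamyl hydroxamate

The source may hold more compounds than are shown below. What is called first, only, known or untested is meant among the compounds shown, and "the series" means these compounds.

Compound 3, with the structure `O=C(NO)c1ccc(-c2cn([C@@H]3C[C@@H](CO)N(CCCc4ccccc4)C3)nn2)cc1`, was tested in an assay on Sf9 cells for inhibition of histone deacetylase 11 (Homo sapiens), read by fluorescence, tested at 0.5 uM (a higher number here means more inhibition at the concentration tested (going by the name of the read-out), a lower number less inhibition), and gave 14%. Among the two numbers that were reported, this is the lowest, but its nearest neighbour, compound 2 with the structure `O=C(/C=C/c1cn([C@H]2C[C@H](CO)N(CCCc3ccccc3)C2)nn1)NO`, gave 16%, only a couple of points higher and within the usual scatter. Compound 1, with the structure `O=C(/C=C/c1cn([C@@H]2C[C@@H](C(=O)O)N(CCCc3ccccc3)C2)nn1)NO`, gave a limit rather than a number in this assay, namely < 10%. Because one of three values sits at this limit (the limit of < 10% in this assay, at which 1 of the 3 values shown sits), the usable spread of the data is narrow.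

Compound 4, with the structure `O=C(/C=C/c1cn([C@@H]2C[C@@H](CO)N(CCCc3ccccc3)C2)nn1)NO`, has not yet been measured. It differs from compound 3 in one place: 2-(hydroxycarbamoyl)ethenyl in place of 4-(hydroxycarbamoyl)phenyl on an aromatic carbon. Within the data shown here, since no measured pair shows this kind of change, its effect in this assay is unknown; the compounds that carry the 2-(hydroxycarbamoyl)ethenyl group, compounds 1 and 2, give either a limit or a value close to that of compound 3. The step from compound 3 to compound 4 is therefore expected to be small, a number 1 percentage points higher from compound 3 to compound 4 (within the scatter), with no direction beyond the scatter. Compound 4 is estimated at 15%, within a range of 5% to 30%.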

Compound 4, a percentage reported as inhibition, at one concentration (the size of the read-out at that concentration, not a potency): 13%
Estimate against measurement, compound 4: 2 percentage points above, and the stated range covers the measured number.
By their numbers in this assay, from the lowest: compounds 4, 3 and 2 (each within the scatter of the next). At a limit, below all of these: compound 1.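

At this position on the aromatic carbon, the ring-free 2-(hydroxycarbamoyl)ethenyl and the 4-(hydroxycarbamoyl)phenyl can now be compared directly in this assay, and the change gives a number 1 percentage points lower from compound 3 to compound 4 (within the scatter). Changing only the configuration as drawn at two saturated ring carbons gives a number 3 percentage points lower from compound 2 to compound 4 (within the scatter), so this pair shows no effect of configuration beyond the scatter at the concentration tested: the fact that compounds 2 and 4 differ only in the configuration as drawn. Hydroxymethyl in place of carboxy on a saturated ring carbon gives a number at least 3 percentage points higher from compound 1 to compound 4 (that floor lies within the scatter), which can be read only as a floor, since the value of compound 1 is a limit: the limit of < 10% in this assay, at which 1 of the 4 values shown sits.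

No step shown here goes beyond the scatter. Going by these compounds, it remains open whether a longer chain carrying the hydroxycarbamoyl group at the aromatic carbon, or an amine in place of hydroxymethyl on the saturated ring carbon, would do so.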